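This account rests on a few compounds, and the source may have more. Where it says the series, first, only, none or still open, it means among the compounds named here.

Compound 1 `CC1=CC[C@H](C(C)(C)NC(=S)N/N=C/c2ccccc2O)CC1`: in a functional assay on PC-3 cells (Homo sapiens) for inhibition, read by sulforhodamine B assay, with a stated time of 48 h (on this read-out lower numbers stand for stronger inhibition of growth and higher numbers for weaker inhibition of growth), compound 1 gives 900 nM.
Compound 2 `CC1=CC[C@H](C(C)(C)NC(=S)N/N=C/c2ccc(F)cc2)CC1`: in this assay compound 2 gives < 900 nM, which is a limit of the assay rather than a number.

Compound 2 thus stands at the limit of < 900 nM in this assay, at which 1 of the 2 values shown sits. Compound 3 `CC1=CC[C@H](C(C)(C)NC(=S)N/N=C/c2ccccc2Cl)CC1` carries 2-chlorophenyl in place of 4-fluorophenyl on a carbon with a double bond to nitrogen. For the measured compounds named here, the only measured step at this carbon is a number no higher from compound 1 to compound 2 (the limit leaves the size open), whose size the limit leaves open. Going by the values given here, with that as the sole guide, compound 3 is expected to stay near the limit in this assay, with no step beyond the scatter foreseen. The estimated step is a step that the limit leaves unreadable from compound 2 to compound 3. Compound 3 is estimated at 600 nM, within a range from 200 nM to 1500 nM.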

Compound 3, concentration for total growth inhibition: 700 nM
For compound 3 the middle estimate is 1.2-fold (0.07 log units) below the measured one, and the stated range covers the measured number.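

Chloro in place of hydroxy on an aromatic carbon gives the first readable step at this place, with a 1.3-fold lower number from compound 1 to compound 3 (0.11 log units; within the scatter) in this assay, so this change leaves the read-out where it was. Compound 2 holds a limit and not a number, so its step to compound 3 cannot be read: the limit of < 900 nM in this assay, at which 1 of the 3 values shown sits.

On these data alone, how 4-fluorophenyl and 2-chlorophenyl truly compare stays open. Also open, as far as these compounds go, is what an amine or a carboxylic acid on that aromatic carbon would give in this assay.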